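The source may report more compounds than this note shows. Statements on the series, on what has been measured and on what is new or still open speak of the compounds shown alone.

Compound 1 `COc1cc(Cl)nc2n/c(=N/C(=O)c3c(-c4ccc(Cl)cc4Cl)noc3C)sn12`: 40.8%
Compound 2 `COc1cc(C)nc(NC(=S)NC(=O)c2c(-c3ccc(Cl)cc3Cl)noc2C)n1`: 61.8%
Compound 3 `COc1cc(C)nc2n/c(=N/C(=O)c3c(-c4ccc(Cl)cc4Cl)noc3C)sn12`: 80.5%

These three compounds were measured in a functional assay on the whole organism (strain L.) for inhibition, with Echinochloa crus-galli as the target, with a stated time of 72 h, tested at 100 mg/L; on this read-out higher numbers stand for more inhibition of growth at the one concentration tested and lower numbers for less inhibition of growth. Compound 2 stands second highest of the three: compound 3 lies above it by a gap beyond the scatter, and compound 1 lies below it by a gap that is also beyond the scatter. Compound 4 `Cc1cc(C)nc(NC(=S)NC(=O)c2c(-c3ccc(Cl)cc3Cl)noc2C)n1` has not yet been measured. It differs from compound 2 in one place: methyl in place of methoxy on an aromatic carbon. Going by the values given here, only one step between measured compounds that differ in one place is known, a number 39.7 percentage points higher from compound 1 to compound 3 (beyond the scatter), and that step concerns a different group elsewhere on the same six-membered aromatic ring with 2 nitrogen. It shows that a change on this ring can move the number a great deal, but it gives no direct guide to methyl in place of methoxy. Lacking a step of the same kind, no move beyond the scatter is expected in this assay. The step of a number 1.8 percentage points lower from compound 2 to compound 4 (within the scatter) is what is expected here. Compound 4 is therefore estimated at 60%, within a range from 40% to 80%.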

Compound 4, percent growth inhibition at one concentration: 64.7%
Beside the measured number, compound 4's estimate is 4.7 percentage points below it; measured number inside the range.
By their numbers in this assay, from the lowest: compound 1; then compounds 2 and 4 (each within the scatter of the next); then compound 3.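

In this assay, going by these compounds alone, going from the 4-methoxy-6-methylpyrimidin-2-yl group to the 4,6-dimethylpyrimidin-2-yl group gives a number 2.9 percentage points higher from compound 2 to compound 4 (within the scatter) as the first direct reading of this change. At this position on the ring, the methoxy with its one hydrogen-bond acceptor can thus give way to methyl with no shift beyond the scatter, unlike the chloro-to-methyl change on the other core, a number 39.7 percentage points higher from compound 1 to compound 3 (beyond the scatter), which was a different swap. Nothing measured here explains why the two groups read alike.

From the compounds shown here alone, whether an amine, a chloro group or a longer chain such as ethoxy would also leave the number in place at this position remains open. So does whether methyl in place of methoxy would read the same way on the core of compound 3.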